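A few compounds are considered here, and "the series" means these few. Any claim that something is new, unique, unknown or untested is made for them only; others in the source may bear on it.

Working notes on the series. Three amides on the shared core have numbers in an assay on THP-1 cells for displacement of a labelled ligand from C-C chemokine receptor type 1 (Homo sapiens); a lower number here means a stronger inhibitor, a higher number a weaker inhibitor. Compound 1 `CC[C@@H](NC(=O)c1ccccc1)C(=O)N1CCC(c2ccc(Cl)cc2)CC1` gives 121 nM. Among the measured compounds shown here, compound 2 `CC[C@@H](C)[C@@H](NC(=O)c1ccccc1)C(=O)N1CCC(c2ccc(Cl)cc2)CC1` gives 45 nM, and the step of a 2.7-fold lower number from compound 1 to compound 2 (0.43 log units; beyond the scatter) is the only single-point step measured so far. Compound 3 `Cc1ccccc1C(=O)N[C@@H](C(=O)N1CCC(c2ccc(Cl)cc2)CC1)C(C)C` gives 32 nM, the lowest of the three numbers; it lies within the scatter of compound 2 and is separated beyond the scatter only from compound 1, so it cannot be called the most potent of the set.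

Compound 4 `Cc1ccc(CCC(=O)N[C@@H](C(=O)N2CCC(c3ccc(Cl)cc3)CC2)C(C)C)cc1` is not yet measured. It differs from compound 3 by 2-(4-methylphenyl)ethyl in place of 2-methylphenyl on a carbonyl carbon. For the measured compounds named here, no measured step bears on this position: the step from compound 1 to compound 2 concerns a saturated chain carbon and says nothing about the group on the carbonyl carbon. All three measured numbers fall in a narrow band, so the working expectation is a step of a 1.6-fold higher number from compound 3 to compound 4 (0.19 log units; within the scatter), not clearly beyond the scatter, with wide uncertainty. Compound 4 is therefore estimated at 50 nM, in the range 12 nM to 220 nM.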

Compound 4, half-maximal inhibitory concentration: 105 nM
Estimate against measurement, compound 4: 2.1-fold (0.32 log units) below; low and high end bracket the measured number.
By their numbers in this assay, from the lowest: compounds 3 and 2 (each within the scatter of the next); then compounds 4 and 1 (each within the scatter of the next).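

Among the compounds shown here, this is the first measured step at the group on the carbonyl carbon: in this assay the change to 2-(4-methylphenyl)ethyl from 2-methylphenyl gives a 3.3-fold higher number from compound 3 to compound 4 (0.52 log units; beyond the scatter) and so shows that this position responds to a change of group. Both groups hold one six-membered aromatic ring of carbon only, and neither brings a hydrogen-bond donor, a hydrogen-bond acceptor or a net charge, so the step appears without a change in any of these counts. No measurement at hand accounts for the step.

The two groups differ both in the chain and in where the methyl sits, and the compounds shown do not separate these two changes. Also open, as far as these compounds go, is how an amine or a carboxylic acid on the aromatic ring of this group would read.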